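A few compounds are considered here, and "the series" means these few. Any claim that something is new, unique, unknown or untested is made for them only; others in the source may bear on it.

Of the compounds shown here, two have been tested in an ADME assay on BEAS-2B cells (Homo sapiens) for cytotoxicity, read by MTT assay, with a stated time of 72 h (a higher number here means a weaker inhibitor of growth, a lower number a stronger inhibitor of growth), so far. Compound 1, `CCOC(=O)Nc1ccc([Se][Se]c2ccc(NC(=O)OCC)cc2)cc1`, gives 16100 nM in this assay. Compound 2, `C=CCOC(=O)Nc1ccc([Se]C#N)cc1`, gives 21400 nM in this assay, the higher of the two numbers, though the gap between compound 1 and compound 2 lies within the usual scatter, so the two cannot be told apart on this evidence.

Compound 3, `N#C[Se]c1ccc(NC(=O)Oc2ccccc2)cc1`, has not yet been measured in this assay. It is made from compound 2 by one change: phenyl in place of allyl on an oxygen next to a carbonyl group. The carbamate nitrogen, the aromatic core and the selenocyanate group are kept unchanged.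

For the measured compounds named here, no measured pair in this small set shows what such a change does to growth inhibition, so the expectation for compound 3 rests on compound 2 alone, which gives 21400 nM in this assay. The step from compound 2 to compound 3 in this assay is expected to be small, a 1.4-fold lower number from compound 2 to compound 3 (0.15 log units; within the scatter), possibly a slightly lower number but not clearly beyond the scatter. Compound 3 is therefore estimated to give 15000 nM in this assay, within a range of 5000 nM to 45000 nM.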

Compound 3, concentration for 50% growth inhibition: 8900 nM
The estimate for compound 3 lay 1.7-fold (0.23 log units) above the measured number; the measured number falls inside the stated range.
By their numbers in this assay, from the lowest: compounds 3, 1 and 2 (each within the scatter of the next, the first and the last beyond it).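

Phenyl in place of allyl on an oxygen next to a carbonyl group gives a 2.4-fold lower number from compound 2 to compound 3 (0.38 log units; beyond the scatter) in this assay and is the first single change in this set whose size can be read, a modest one that lies beyond the scatter. With the carbamate nitrogen, the aromatic core and the selenocyanate group kept, the group on this oxygen is thus shown to matter on its own: the change from allyl, with 3 heavy atoms and no ring, to phenyl, with 6 heavy atoms and one aromatic ring, is enough to move the number toward stronger inhibition of growth. The data offer no measured basis for saying why this change has that effect.

Going by these compounds, with only allyl and phenyl compared at this position, it stays open whether the aromatic ring or simply the larger group goes with the lower number, a question that cyclohexyl or a longer chain such as butyl on the same oxygen would address. On these data alone, it also stays open whether phenyl would have a similar effect on the core of compound 1, or whether an amine or a carboxylic acid on the phenyl ring would keep the step.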